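A Methoxy Swap on an Inactive Compound

A few compounds are considered here, and "the series" means these few. Any claim that something is new, unique, unknown or untested is made for them only; others in the source may bear on it.

Compound 1 (`O=C(N/N=C/c1cccc([N+](=O)[O-])c1)Nc1ccc(Oc2ccnc3[nH]ccc23)c(F)c1`) has no number to its name: in a functional assay on MCF7 cells (Homo sapiens) for antiproliferative activity, read by MTT assay, with a stated time of 72 h (a lower number here means a stronger inhibitor, a higher number a weaker inhibitor), compound 1 gives "not active" (no number reported). Two relatives share its core. Compound 2 (`O=C(N/N=C/c1ccc(F)cc1Cl)Nc1ccc(Oc2ccnc3[nH]ccc23)c(F)c1`) gives 7610 nM, the only figure available so far, whereas compound 3 (`O=C(N/N=C/c1ccc(O)cc1)Nc1ccc(Oc2ccnc3[nH]ccc23)c(F)c1`) gives "not active" (no number reported). Compound 1 therefore stands with compound 3 among the entries without a number.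

Compound 4 (`COc1ccc(/C=N/NC(=O)Nc2ccc(Oc3ccnc4[nH]ccc34)c(F)c2)cc1`) has not yet been measured. It keeps the core of compound 1 and changes a single group, with 4-methoxyphenyl in place of 3-nitrophenyl on a carbon with a double bond to nitrogen.

Within the data shown here, no measured pair shows what a single change does here, so any forecast is rough. In this assay I expect at most a small move towards measurable activity, and possibly no reading at all. Compound 2 at 7610 nM is the only reference point. If a number appears, compound 4 is expected near 15000 nM, within an estimated range of 5000 nM to 45000 nM.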

Compound 4, half-maximal inhibitory concentration: 5750 nM
Beside the measured number, compound 4's estimate is 2.6-fold (0.42 log units) above it, and the stated range covers the measured number.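

In this assay the carbon with a double bond to nitrogen can carry a group that gives a measurable reading: compound 1, with 3-nitrophenyl, gives "not active" (no number reported) while compound 4, with 4-methoxyphenyl, gives 5750 nM on the same core. Among these compounds, that swap has no size, since compound 1 offers no number to start from; the only step that can be read is a 1.3-fold lower number from compound 2 to compound 4 (0.12 log units; within the scatter) and it leaves 4-methoxyphenyl and 2-chloro-4-fluorophenyl indistinguishable at this position. No measurement here bears on why a reading appears with 4-methoxyphenyl.

Still open, on these data alone, is how a phenyl ring carrying an amine or a longer ether chain in place of the methoxy group would read at this position. Also open, as far as these compounds go, is whether any group on this carbon can give a clearly lower number than compound 2 and compound 4 do.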